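The source may report more compounds than this note shows. Statements on the series, on what has been measured and on what is new or still open speak of the compounds shown alone.

In a functional assay on V79-379A cells (Cricetulus griseus) for cytotoxicity, read by MTT assay, in the presence of a further agent that is not named here (a higher number here means a weaker inhibitor, a lower number a stronger inhibitor), compound 1 `COC1=CC(=O)c2c(c(COC(=O)c3ccccc3)c(C)n2C)C1=O` gives 16000 nM, while compound 2 `COC1=CC(=O)c2c(c(COC(N)=O)cn2C)C1=O` gives 3000 nM. Compound 2 therefore holds the lower of the two numbers, and the gap between them lies beyond the scatter. Compound 3 `COC1=CC(=O)c2c(c(COC(N)=O)c(C)n2C)C1=O` keeps the (carbamoyloxy)methyl group of compound 2 and makes one change: methyl in place of hydrogen on an aromatic carbon. The new methyl sits next to the ring nitrogen. For the measured compounds named here, compound 1 also carries a methyl there, but it differs from compound 2 in its other side group as well, so no measured pair shows the methyl on its own. With so little to go on, the expectation in this assay is for no step beyond the scatter, with a slightly higher number if anything. The expected change is a 1.2-fold higher number from compound 2 to compound 3 (0.07 log units; within the scatter). For compound 3 the estimated value is 3500 nM, with an expected range from 1200 nM to 10000 nM.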

Compound 3, half-maximal inhibitory concentration: 25000 nM
Estimate against measurement, compound 3: 7.1-fold (0.85 log units) below, outside the stated range (above it).
By their numbers in this assay, from the lowest: compound 2; then compounds 1 and 3 (each within the scatter of the next).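

In this assay, for the compounds shown here, putting a methyl in place of hydrogen on this aromatic carbon, next to the ring nitrogen, gives an 8.3-fold higher number from compound 2 to compound 3 (0.92 log units; beyond the scatter), so this one small addition counts on its own, which no earlier pair could show. With that methyl present, amino in place of phenyl on a carbonyl carbon gives a 1.6-fold higher number from compound 1 to compound 3 (0.19 log units; within the scatter), so these two side groups cannot be told apart on the methyl-bearing core. No measurement at hand bears on the cause of the methyl step.

From the compounds shown here alone, it remains open whether an ethyl group, a longer chain or an amine on the same carbon would behave like the methyl. Going by these compounds, it also remains open how the phenyl-bearing side group of compound 1 behaves when hydrogen replaces that methyl.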